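Swapping the pyridinyl group on the amine of the shared core

This account rests on a few compounds, and the source may have more. Where it says the series, first, only, none or still open, it means among the compounds named here.

Three compounds have been measured in an ADME assay on microsomes from liver (Mus musculus) for metabolic stability, read by LC-MS, with a stated time of 30 min, tested at 0.1 uM; a higher number here means that more of the compound is left, a lower number that less of the compound is left:

compound 1 `COc1ccnc(Nc2cc3[nH]c(-c4cccc(C(F)(F)F)c4)nc3cn2)c1` gives 62%
compound 2 `Fc1ccc(-c2nc3cnc(Nc4ccccn4)cc3[nH]2)cc1C(F)(F)F` gives 64%
compound 3 `Fc1ccc(-c2nc3cnc(Nc4ccccn4)cc3[nH]2)cc1F` gives 7.5%

Compound 1 stands second highest of the three in this assay. Its nearest neighbour is compound 2, whose value lies within the scatter of compound 1; its furthest is compound 3, which lies well below. Among the measured compounds shown here, the single step measured between neighbouring structures is a number 56.5 percentage points lower from compound 2 to compound 3 (beyond the scatter), a change on the aryl ring attached to the shared core.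

Compound 4 `N#Cc1ccc(Nc2cc3[nH]c(-c4cccc(C(F)(F)F)c4)nc3cn2)nc1` differs from compound 1 by 5-cyanopyridin-2-yl in place of 4-methoxypyridin-2-yl on a nitrogen on an aromatic ring. For the measured compounds named here, this change sits on the amine side of the core, not on the aryl ring where the measured step was taken, so no measured step bears directly on it. With no guidance from the data, the step is expected to stay within the usual scatter, a number 7 percentage points lower from compound 1 to compound 4 (within the scatter). Compound 4 is therefore estimated to give 55% in this assay, expected within the range 30% to 80%.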

Compound 4, percent of the compound remaining: 47%
The estimate for compound 4 lay 8 percentage points above the measured number, within the range that was stated.
By their numbers in this assay, from the lowest: compound 3; then compound 4; then compounds 1 and 2 (each within the scatter of the next).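

Swapping 5-cyanopyridin-2-yl for 4-methoxypyridin-2-yl on the amine side of the shared core gives the first reading at this position in this assay: a number 15 percentage points lower from compound 1 to compound 4 (beyond the scatter) and so shows that this side of the molecule can move the number too, though the step is far smaller than a number 56.5 percentage points lower from compound 2 to compound 3 (beyond the scatter) on the aryl ring. The swap changes both the substituent and where it sits on the pyridine, so this single step cannot separate the two changes. Nothing available here explains the step.

Going by these compounds, it remains open whether the nitrile itself or the loss of the methoxy group accounts for the step. The compounds shown also leave open how a 5-methoxypyridin-2-yl group, or a pyridine carrying an amine or a carboxylic acid, would behave on this nitrogen.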